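Quinazoline thioacetamides: swapping the aniline substituent

A few compounds are considered here, and "the series" means these few. Any claim that something is new, unique, unknown or untested is made for them only; others in the source may bear on it.

Compound 1 `O=C(CSc1nc(Nc2ccccc2)c2ccccc2n1)Nc1cccc(Br)c1` gives 11400 nM in a functional assay on PC-3 cells (Homo sapiens) for inhibition, read by MTT assay, with a stated time of 72 h; on this read-out lower numbers stand for stronger inhibition and higher numbers for weaker inhibition.
Compound 2 `O=C(CSc1nc(Nc2ccccc2)c2ccccc2n1)Nc1ccc(F)c(Cl)c1` gives 15500 nM in this assay.
Compound 3 `C=CC(=O)Nc1cccc(NC(=O)CSc2nc(Nc3ccccc3F)c3ccccc3n2)c1` gives 9340 nM in this assay.

Among these three, compound 3 carries the lowest number, but its distance to compound 1 and to compound 2 lies within the scatter, so the three stand together rather than in any order. Going by the values given here, the only step measured between neighbours, a 1.4-fold higher number from compound 1 to compound 2 (0.13 log units; within the scatter), changes the amide-type nitrogen and stays within the scatter.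

Compound 4 `C=CC(=O)Nc1cccc(NC(=O)CSc2nc(Nc3cccc(OC)c3)c3ccccc3n2)c1` is not yet measured. It differs from compound 3 at the other end of the shared core: 3-methoxyphenyl in place of 2-fluorophenyl on a nitrogen on an aromatic ring. Among the compounds with values here, no measured pair touches this nitrogen, so the one measured step does not speak to it directly; it only shows that the series so far has moved little on any change tried. With no evidence for a shift at this position, the expected step of a 1.0-fold higher number from compound 3 to compound 4 (0.01 log units; within the scatter) is one that stays inside the scatter, in no set direction. Compound 4 is therefore estimated at 9500 nM, with a range from 4000 nM to 22000 nM in this assay.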

Compound 4, half-maximal inhibitory concentration: 34900 nM
Compound 4: middle estimate off by 3.7-fold (0.57 log units), on the low side; the measured number lies above the stated range.
By their numbers in this assay, from the lowest: compounds 3, 1 and 2 (each within the scatter of the next); then compound 4.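

This is the only step shown that lies beyond the scatter: putting 3-methoxyphenyl in place of 2-fluorophenyl on the nitrogen on an aromatic ring gives a 3.7-fold higher number from compound 3 to compound 4 (0.57 log units; beyond the scatter), and on this read-out a higher number stands for weaker inhibition. Going by these compounds alone, the group on this nitrogen can therefore change the result, whereas the one earlier step, a 1.4-fold higher number from compound 1 to compound 2 (0.13 log units; within the scatter), was made on the amide-type nitrogen and stayed within the scatter. Nothing available here accounts for the rise in the number.

The two phenyl groups differ both in their substituent and in its numbered place on the ring, so this single step cannot separate those two changes, and compound 1 and compound 2 cannot settle it, since they differ from compound 3 and compound 4 in more than one place. Still open, on these data alone, is how 3-fluorophenyl or 2-methoxyphenyl would read on this nitrogen, and whether an amine or a carboxylic acid on that phenyl ring would move the number at all.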